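The source may hold more compounds than are shown below. What is called first, only, known or untested is meant among the compounds shown, and "the series" means these compounds.

Three compounds have been measured in a functional assay on PC-3 cells (Homo sapiens) for cytotoxicity, read by MTT assay, with a stated time of 72 h; a higher number here means a weaker inhibitor, a lower number a stronger inhibitor:

compound 1, `Cc1ccc(-c2ccnc(C(=O)Nc3ccc(Oc4ccnc5[nH]ccc45)cc3)c2)cc1`, sits at a limit of the assay rather than a number, > 10000 nM.
compound 2, `Cc1cccc(-c2ccnc(C(=O)Nc3ccc(Oc4ccnc5[nH]ccc45)cc3)c2)c1`, gives 5470 nM.
compound 3, `Cc1cccc(-c2ccnc(C(=O)Nc3ccc(Oc4ccnc5[nH]ccc45)c(F)c3)c2)c1`, gives 860 nM.

Compound 3 is built from compound 2 by fluoro in place of hydrogen on an aromatic carbon, and this step gave a 6.4-fold lower number from compound 2 to compound 3 (0.80 log units; beyond the scatter). Compound 1 is built from compound 2 by 4-methylphenyl in place of 3-methylphenyl on an aromatic carbon, and this step gave an at least 1.8-fold higher number from compound 2 to compound 1 (0.26 log units; that floor lies within the scatter); the size of that step is only known as a floor because of the limit of > 10000 nM in this assay, at which 1 of the 3 values shown sits.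

Compound 4, `Cc1ccc(-c2ccnc(C(=O)Nc3ccc(Oc4ccnc5[nH]ccc45)c(F)c3)c2)cc1`, is not yet measured. Within the data shown here, it is built from compound 3 by 4-methylphenyl in place of 3-methylphenyl on an aromatic carbon, the same change as the one that turned compound 2 into compound 1, at the same place. Within the pair, compound 3 holds the lowest number of the two that were measured, with compound 2 as its nearest neighbour.

Beside an at least 1.8-fold higher number from compound 2 to compound 1 (0.26 log units; that floor lies within the scatter), compound 4 is expected to show a 3.5-fold higher number from compound 3 to compound 4 (0.54 log units; beyond the scatter), a worsening resting on the step already seen from compound 2 to compound 1. Compound 4 is therefore estimated at about 3000 nM, most likely between 1200 nM and 10000 nM.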

Compound 4, half-maximal inhibitory concentration: 3970 nM
For compound 4 the middle estimate is 1.3-fold (0.12 log units) below the measured one; low and high end bracket the measured number.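

Carrying 4-methylphenyl in place of 3-methylphenyl onto the fluoro-bearing core of compound 3 gave, in this assay, a 4.6-fold higher number from compound 3 to compound 4 (0.66 log units; beyond the scatter), a clear worsening, whereas on the core of compound 2 the same change is known only as a floor that does not clear the scatter: the same change on two cores in this assay, an at least 1.8-fold higher number (0.26 log units; that floor lies within the scatter) from compound 2 to compound 1 and a 4.6-fold higher number (0.66 log units; beyond the scatter) from compound 3 to compound 4; the limit leaves it open whether they differ
Fluoro in place of hydrogen also lowered the number when the 4-methylphenyl group was present, with an at least 2.5-fold lower number from compound 1 to compound 4 (0.40 log units; beyond the scatter), which matches the direction seen with the 3-methylphenyl group: the same change on two cores in this assay, a 6.4-fold lower number (0.80 log units; beyond the scatter) from compound 2 to compound 3 and an at least 2.5-fold lower number (0.40 log units; beyond the scatter) from compound 1 to compound 4; the limit leaves it open whether they differ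
Both changes therefore keep their direction across the two cores in these four compounds, but this does not show that either keeps its size, as compound 1 stands at a limit and not at a number: the limit of > 10000 nM in this assay, at which 1 of the 4 values shown sits.

The compounds shown leave open how an unsubstituted phenyl or a methoxyphenyl group would behave at the same place. They also leave open whether chloro in place of fluoro would lower the number in the same way.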